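The source may hold more compounds than are shown below. What is called first, only, known or untested is meant among the compounds shown, and "the series" means these compounds.

In a functional assay on DLA cells (Mus musculus) for cytotoxicity, read by MTT assay, with a stated time of 48 h (on this read-out lower numbers stand for stronger inhibition and higher numbers for weaker inhibition), compound 1 `Cc1cc(C(=O)c2ccccc2)ccc1OCC(=O)Nc1nc(-c2ccccc2)cs1` gives 22300 nM. Compound 2 `COc1ccc(-c2csc(NC(=O)COc3ccc(C(=O)c4ccccc4)cc3C)n2)cc1` gives 25700 nM in this assay, and compound 3 `Cc1ccc(C(=O)c2ccc(OCC(=O)Nc3nc(-c4ccccc4)cs3)c(C)c2)cc1` gives 26400 nM. Compound 2 thus holds the second highest of the three numbers; its nearest neighbour is compound 3 and its furthest is compound 1, and both gaps lie within the scatter, so these numbers do not separate the three. The step of a 1.2-fold higher number from compound 1 to compound 2 (0.06 log units; within the scatter) and the step of a 1.2-fold higher number from compound 1 to compound 3 (0.07 log units; within the scatter) likewise stay within the scatter.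

Compound 4 `COc1ccc(-c2csc(NC(=O)COc3ccc(C(=O)c4ccc(C)cc4)cc3C)n2)cc1` differs from compound 2 in one place: methyl in place of hydrogen on an aromatic carbon. Read one bond further out, the benzoyl becomes a (4-methylphenyl)carbonyl. The measured step that bears most directly on this change is a 1.2-fold higher number from compound 1 to compound 3 (0.07 log units; within the scatter), the same methyl for hydrogen at the same place, and it stayed within the scatter; a 1.2-fold higher number from compound 1 to compound 2 (0.06 log units; within the scatter) shows the shared core taking a small added group without a change beyond the scatter either. No step beyond the scatter is therefore expected in this assay, and the expected step is a 1.1-fold higher number from compound 2 to compound 4 (0.02 log units; within the scatter). Compound 4 is expected to give about 27000 nM in this assay, with a range from 12000 nM to 60000 nM.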

Compound 4, half-maximal inhibitory concentration: 17200 nM
Estimate against measurement, compound 4: 1.6-fold (0.20 log units) above; low and high end bracket the measured number.
By their numbers in this assay, from the lowest: compounds 4, 1, 2 and 3 (each within the scatter of the next).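

In this assay, methyl in place of hydrogen on the phenyl ring of the benzoyl, now read on a second core, gives a 1.5-fold lower number from compound 2 to compound 4 (0.17 log units; within the scatter), and methoxy in place of hydrogen on a core that already holds the 4-methylphenyl gives a 1.5-fold lower number from compound 3 to compound 4 (0.19 log units; within the scatter). Each change has now been read on two cores, and the methyl change shows no difference between them beyond the scatter of two such steps: the same change on two cores in this assay, a 1.2-fold higher number (0.07 log units; within the scatter) from compound 1 to compound 3 and a 1.5-fold lower number (0.17 log units; within the scatter) from compound 2 to compound 4, 1.8-fold (0.25 log units) apart, within the scatter of two such steps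

The methoxy change, compared in the same way, reads alike: the same change on two cores in this assay, a 1.2-fold higher number (0.06 log units; within the scatter) from compound 1 to compound 2 and a 1.5-fold lower number (0.19 log units; within the scatter) from compound 3 to compound 4, 1.8-fold (0.25 log units) apart, within the scatter of two such steps

The compounds shown carry only hydrogen or methyl at this aromatic carbon, so they leave open whether an amine, a carboxylic acid or a longer chain there would move the number beyond the scatter. With each of the four numbers within the scatter of the next, they also leave open whether the methoxy on the other aromatic ring could be exchanged for a hydroxyl or an amine with any step beyond the scatter in this assay.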